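The compounds below may be only part of what the source reports. "The series", "measured", "known", "first", "only" and "open" are said of these compounds alone.

Measured in a functional assay on U-373MG ATCC cells (Homo sapiens) for inhibition, read by MTT assay, with a stated time of 72 h; on this read-out higher numbers stand for weaker inhibition and lower numbers for stronger inhibition:
- Compound 1 `CC1(C)CC(NC(=O)Nc2cccc(Cl)c2)c2cc(Br)ccc2O1`: 69000 nM
- Compound 2 `CC1(C)CC(NC(=O)Nc2ccccc2Cl)c2cc(F)ccc2O1`: 40000 nM
- Compound 3 `CC1(C)CC(NC(=O)Nc2ccc(Cl)cc2)c2cc(F)ccc2O1`: 24000 nM

Compound 3 and compound 2 lie within the scatter of each other, while compound 1 has a higher number than compound 3, beyond the scatter. Compound 4 `CC1(C)CC(NC(=O)Nc2cccc(Cl)c2)c2cc(F)ccc2O1` is still unmeasured. It puts 3-chlorophenyl in place of 4-chlorophenyl on an amide-type nitrogen. The closest guide is a similar swap, a 1.7-fold lower number from compound 2 to compound 3 (0.22 log units; within the scatter), which replaced 2-chlorophenyl with 4-chlorophenyl. Compound 1 carries 3-chlorophenyl on a different core, so its value says less. A similarly small change is expected here, with a 1.3-fold higher number from compound 3 to compound 4 (0.10 log units; within the scatter) estimated to stay within the scatter. Compound 4 is estimated at 30000 nM, with an expected range of 15000 nM to 60000 nM.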

Compound 4, half-maximal inhibitory concentration: 39000 nM
The estimate for compound 4 lay 1.3-fold (0.11 log units) below the measured number; low and high end bracket the measured number.
By their numbers in this assay, from the lowest: compounds 3, 4, 2 and 1 (each within the scatter of the next, the first and the last beyond it).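

With 2-chlorophenyl, 3-chlorophenyl and 4-chlorophenyl now all seen on the shared core, the three cannot be told apart on this read-out: both steps to 3-chlorophenyl stay within the scatter (a 1.6-fold higher number from compound 3 to compound 4 (0.21 log units; within the scatter); a 1.0-fold lower number from compound 2 to compound 4 (0.01 log units; within the scatter)). Fluoro in place of bromo on the aromatic carbon, now seen as a single change, also stays within the scatter (a 1.8-fold lower number from compound 1 to compound 4 (0.25 log units; within the scatter)). No measured evidence explains these results. Still open, going by these compounds, is whether a methoxy group, a nitrile or a carboxylic acid in place of the chlorine on the phenyl ring would shift the number beyond the scatter.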